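The source may hold more compounds than are shown below. What is called first, only, known or untested is meant among the compounds shown, and "the series" means these compounds.

Among the measured compounds shown here, in a functional assay on HCT-116 cells (Homo sapiens) for inhibition, read by MTT assay, with a stated time of 48 h (on this read-out higher numbers stand for weaker inhibition and lower numbers for stronger inhibition), the compounds so far cluster at the limit of > 60000 nM in this assay, at which 2 of the 3 values shown sit. Compound 1 `COc1cc(-c2nnc(SC)n2-c2ccc(N(C)C)cc2)cc(OC)c1OC`, which has only a hydrogen on the saturated chain carbon bound to sulfur, reaches a limit of the assay, > 60000 nM. Compound 3 `COc1cc(-c2nnc(SCC(=O)C3CC3)n2-c2ccc(N(C)C)cc2)cc(OC)c1OC`, with cyclopropylcarbonyl at that carbon, also gives only a limit, > 60000 nM. Compound 2 `COc1cc(-c2nnc(SCC(=O)c3ccc4ccccc4c3)n2-c2ccc(N(C)C)cc2)cc(OC)c1OC`, with (naphthalen-2-yl)carbonyl instead, gives a real number, 54500 nM.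

Compound 4 `COc1ccc(NC(=O)CSc2nnc(-c3cc(OC)c(OC)c(OC)c3)n2-c2ccc(N(C)C)cc2)cc1` keeps the core and changes the group on the carbonyl carbon of compound 3: (4-methoxyphenyl)amino in place of cyclopropyl on a carbonyl carbon. Cyclopropylcarbonyl thus becomes (4-methoxyphenyl)carbamoyl.

For the measured compounds named here, the nearest precedent is the change between cyclopropyl and naphthalen-2-yl on that carbonyl, an at least 1.1-fold higher number from compound 2 to compound 3 (0.04 log units; that floor lies within the scatter). The step of an at least 1.1-fold lower number from compound 1 to compound 2 (0.04 log units; that floor lies within the scatter) is equally small, while a step that the two limits leave unreadable from compound 1 to compound 3. Neither readable step shows a clear gain, so only a small move toward a lower number is expected, an at least 1.3-fold lower number from compound 3 to compound 4 (0.12 log units; that floor lies within the scatter). Compound 4 is estimated at 45000 nM, with an expected range of 15000 nM to 90000 nM.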

Compound 4, half-maximal inhibitory concentration: > 60000 nM
Compound 4: no number, only a limit (the forecaster's own chance of this, stated with the estimate: 50%); at least 1.3-fold (0.12 log units) between middle value and limit.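

In this assay the series now gathers even more tightly at one ceiling: the limit of > 60000 nM in this assay, at which 3 of the 4 values shown sit.

Putting (4-methoxyphenyl)amino in place of cyclopropyl on the carbonyl carbon adds an aromatic ring and a hydrogen-bond donor, yet the result is still a limit and not a number, so the steps from compound 1 and from compound 3 to compound 4 cannot be read. Compared with compound 2, the only compound with a real number, the change gives an at least 1.1-fold higher number from compound 2 to compound 4 (0.04 log units; that floor lies within the scatter), so an aromatic group on this carbonyl has not yet produced a clear gain.

From the compounds shown here alone, it remains open whether a carboxylic acid or a piperidine in place of (4-methoxyphenyl)amino would give a number well clear of the limit. Also open, going by these compounds, is whether a longer chain on the sulfur would do so.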